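The source may report more compounds than this note shows. Statements on the series, on what has been measured and on what is new or still open speak of the compounds shown alone.

Measured so far in a functional assay on HeLa cells (Homo sapiens) for antiproliferative activity, read by CCK-8 assay, with a stated time of 48 h; a lower number here means a stronger inhibitor, a higher number a weaker inhibitor:
compound 1 `O=c1c2ccccc2[se]n1-c1nc(SCc2ccc(Cl)cc2)n[nH]1` gives 40900 nM
compound 2 `Cc1ccccc1CSc1n[nH]c(-n2[se]c3ccccc3c2=O)n1` gives 6130 nM
compound 3 `CCCCSc1n[nH]c(-n2[se]c3ccccc3c2=O)n1` gives 32900 nM

Compound 3 stands second highest of the three numbers. Its nearest neighbour is compound 1, with the step of a 1.2-fold lower number from compound 1 to compound 3 (0.09 log units; within the scatter) lying within the scatter; its furthest is compound 2, the step of a 5.4-fold higher number from compound 2 to compound 3 (0.73 log units; beyond the scatter) being a modest one beyond it.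

Compound 4 `CCCCCSc1n[nH]c(-n2[se]c3ccccc3c2=O)n1` differs from compound 3 by methyl in place of hydrogen on a saturated chain carbon, four bonds along the chain from a sulfur. The measured steps, a 6.7-fold lower number from compound 1 to compound 2 (0.82 log units; beyond the scatter), a 1.2-fold lower number from compound 1 to compound 3 (0.09 log units; within the scatter) and a 5.4-fold higher number from compound 2 to compound 3 (0.73 log units; beyond the scatter), all swap one group for another on the chain carbon bound to the sulfur; none extends a chain outward, so none bears directly on this change. With nothing of the kind measured, no step beyond the scatter is expected; the estimated step is a 1.0-fold higher number from compound 3 to compound 4 (0.00 log units; within the scatter). Compound 4 is estimated at 33000 nM, in the range 12000 nM to 90000 nM.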

Compound 4, half-maximal inhibitory concentration: 30300 nM
Compound 4: middle estimate off by 1.1-fold (0.04 log units), on the high side; measured number inside the range.
By their numbers in this assay, from the lowest: compound 2; then compounds 4, 3 and 1 (each within the scatter of the next).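

In this assay, extending the chain at this position gives a 1.1-fold lower number from compound 3 to compound 4 (0.04 log units; within the scatter), so methyl in place of hydrogen, four bonds along the chain from a sulfur, shows no step beyond the scatter. Butyl differs from 2-methylphenyl by a 4.9-fold higher number from compound 2 to compound 4 (0.69 log units; beyond the scatter) but not from 4-chlorophenyl, with a 1.3-fold lower number from compound 1 to compound 4 (0.13 log units; within the scatter), and compound 2 remains the strongest of the four. No measured evidence accounts for these numbers. As far as these compounds go, whether a longer chain, or an amine or a carboxylic acid at the chain end, would give a step beyond the scatter remains open.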